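The compounds below may be only part of what the source reports. "The series", "measured", "known", "first", "only" and "open" are said of these compounds alone.

The measured compounds:
Compound 1 `Nc1nc(O)c2nnn(C3CC(CO)C(O)C3O)c2n1` gives > 100 ug/mL in a functional assay on cells (Cancer cell lines, Homo sapiens) for cytotoxicity (on this read-out higher numbers stand for an effect only at larger amounts of compound and lower numbers for an effect already at smaller amounts), a limit of the assay rather than a number.
Compound 2 `CNc1nc(N)nc2c1ncn2C1CC(CO)C(O)C1O` gives 18 ug/mL in this assay.
Compound 3 `CSc1nc(N)nc2c1ncn2C1CC(CO)C(O)C1O` gives > 100 ug/mL in this assay, again a limit of the assay and not a number.

Compound 1 thus stands at the top of the range seen here, at the same limit as compound 3 (the limit of > 100 ug/mL in this assay, at which 2 of the 3 values shown sit). Compound 4 `CSc1nc(N)nc2c1nnn2C1CC(CO)C(O)C1O` differs from compound 1 by methylsulfanyl in place of hydroxy on an aromatic carbon. For the measured compounds named here, no measured pair covers this exact change. Going by the values given here, the one step that bears on it is an at least 5.5-fold higher number from compound 2 to compound 3 (0.74 log units; beyond the scatter), where methylsulfanyl entered on a different core and the number rose to the limit. Compound 1 already sits at that limit, so compound 4 is expected to remain there, with a step that the limit leaves unreadable from compound 1 to compound 4 not beyond the scatter. Compound 4 is estimated at 150 ug/mL in this assay, between 60 ug/mL and 400 ug/mL.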

Compound 4, concentration for half-maximal effect: > 100 ug/mL
Compound 4 was reported as a limit; the forecaster's own chance of this, stated with the estimate: 80%; the middle value does not contradict the limit.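

Compound 4 gives > 100 ug/mL in this assay as a limit of the assay and not a number. Compound 1 also stands at a limit, so no step between compound 1 and compound 4 can be read: the limit of > 100 ug/mL in this assay, at which 3 of the 4 values shown sit.

The compounds shown leave open whether methylsulfanyl in place of hydroxy changes the number at all on this core.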